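Propargyl in place of methyl on two related cores

This account rests on a few compounds, and the source may have more. Where it says the series, first, only, none or still open, it means among the compounds named here.

Three measured compounds share a long side chain of two acidic amino-acid units but differ in the core that carries it. Compound 1 `Cc1nc(O)c2cc(CN(C)c3ccc(C(=O)N[C@@H](CCC(=O)O)C(=O)N(C)[C@@H](CCC(=O)O)C(=O)O)c(F)c3)ccc2n1` gives 2400 nM in a functional assay (L1210 cells) for inhibition, with Mus musculus as the target; a lower number here means a stronger inhibitor, a higher number a weaker inhibitor. Compound 3 `Cc1nc(O)c2cc(CN(C)c3ccc(C(=O)N[C@@H](CCC(=O)O)C(=O)N(C)[C@@H](CCC(=O)O)C(=O)O)cc3)c(C)cc2n1` reaches 640 nM, and compound 2 `C#CCN(Cc1cc2c(O)nc(C)nc2cc1C)c1ccc(C(=O)N[C@@H](CCC(=O)O)C(=O)N(C)[C@@H](CCC(=O)O)C(=O)O)cc1` reaches 220 nM. The difference between the cores of compound 1 and compound 3 is not broken down here.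

Compound 2 arises from compound 3 by one change, (ethynyl in place of hydrogen on a saturated chain carbon bound to a nitrogen on an aromatic ring); this gives a 2.9-fold lower number from compound 3 to compound 2 (0.46 log units; beyond the scatter). Compound 4 `C#CCN(Cc1ccc2nc(C)nc(O)c2c1)c1ccc(C(=O)N[C@@H](CCC(=O)O)C(=O)N(C)[C@@H](CCC(=O)O)C(=O)O)c(F)c1` carries the same change on the core of compound 1: ethynyl in place of hydrogen on a saturated chain carbon bound to a nitrogen on an aromatic ring, at the very same place in the words of the two descriptions.

Among the compounds with values here, because the earlier step of a 2.9-fold lower number from compound 3 to compound 2 (0.46 log units; beyond the scatter) was measured on a different core, it is the only guide available, and the expectation is that the change made from compound 1 to compound 4 gives a step of similar size, a 2.9-fold lower number from compound 1 to compound 4 (0.46 log units; beyond the scatter). On that basis compound 4 is estimated at 830 nM, most likely between 350 nM and 2000 nM.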

Compound 4, half-maximal inhibitory concentration: 230 nM
Estimate against measurement, compound 4: 3.6-fold (0.56 log units) above; measured number below the stated range.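

On the core of compound 1, replacing methyl with propargyl gives a 10-fold lower number from compound 1 to compound 4 (1.02 log units; beyond the scatter) in this assay. The change lowers the number on both cores, so its direction carries over in these two pairs, but its size does not: the same change on two cores in this assay, a 2.9-fold lower number (0.46 log units; beyond the scatter) from compound 3 to compound 2 and a 10-fold lower number (1.02 log units; beyond the scatter) from compound 1 to compound 4, 3.6-fold (0.55 log units) apart, beyond the scatter of two such steps

A step measured on one core was therefore a fair guide to direction here but a poor guide to size, and two pairs cannot show which of the differences between the cores goes with the larger step.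

The compounds shown leave open whether the gain depends on the triple bond or simply on a longer chain, which a plain propyl group on the same nitrogen would help to separate. Also open, from the compounds shown here alone, is how the methyl to propargyl change would behave on a third core, for example one with a chlorine in place of the fluorine of compound 1.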